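A few compounds are considered here, and "the series" means these few. Any claim that something is new, unique, unknown or untested is made for them only; others in the source may bear on it.

In an ADME assay on the whole organism (strain Sprague-Dawley) for pharmacokinetics, with Rattus norvegicus as the target (on this read-out lower numbers stand for narrower distribution and higher numbers for wider distribution into tissues), compound 1 `Nc1nc(Nc2ccc(N3CCN(C4CC5CCC4C5)CC3)cc2)nn1-c1ncnc2ccc(Cl)cc12` stands at "not determined" (no result reported) with no number reported. Going by the values given here, compound 2 `Cc1csc2c(-n3nc(Nc4ccc(N5CCN(C6CC7CCC6C7)CC5)cc4)nc3N)nc(Cl)nc12` gives 4.4 L/kg as the only number so far, so it has no rank against any other compound. Compound 3 `Nc1nc(Nc2ccc(N3CCN(C4CC5CCC4C5)CC3)cc2)nn1-c1ncnc2ccc(F)cc12` brings one change from compound 2: a group of 11 heavy atoms (8 carbon, 2 nitrogen, 1 fluorine; one six-membered aromatic ring of carbon only, one six-membered aromatic ring with 2 hetero atoms) in place of a group of 11 heavy atoms (7 carbon, 2 nitrogen, 1 sulfur, 1 chlorine; one five-membered aromatic ring with 1 hetero atom, one six-membered aromatic ring with 2 hetero atoms), on an aromatic nitrogen on an aromatic nitrogen. Among the compounds with values here, no measured step exists to guide the size of this change. No shift beyond the scatter is expected in this assay in either direction, and a 1.1-fold lower number from compound 2 to compound 3 (0.04 log units; within the scatter) is the estimated move. For compound 3 the estimated value is 4 L/kg with an expected range from 1.8 L/kg to 9 L/kg on this read-out.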

Compound 3, volume of distribution at steady state: 7.9 L/kg
The estimate for compound 3 lay 2.0-fold (0.30 log units) below the measured number; low and high end bracket the measured number.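

In this assay, placing 6-fluoroquinazolin-4-yl on the aromatic nitrogen in place of the sulfur- and chlorine-bearing group gives a 1.8-fold higher number from compound 2 to compound 3 (0.25 log units; within the scatter). This position therefore tolerates this exchange of two groups of equal heavy-atom count without a shift beyond the scatter on this read-out. No measured data here bear on the result. Going by these compounds, whether a group carrying an amine or a carboxylic acid at this position would move the read-out beyond the scatter stays open. This single step also cannot separate the exchange of the ring from that of the halogen.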